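The compounds below may be only part of what the source reports. "The series", "measured", "known", "first", "only" and "open" are said of these compounds alone.

Values in an ADME assay on CHO cells (Cricetulus griseus) for cytotoxicity, read by MTT assay; a higher number here means a weaker inhibitor, a lower number a stronger inhibitor:
- compound 1 `C=CCN1CCC(CNc2ccnc3ccccc23)C(C)(C)C1`: 27000 nM
- compound 2 `C=CCN1C[C@@H](OCc2ccccc2)[C@@H](CNCc2ccc3ccccc3n2)C(C)(C)C1`: 211000 nM
- compound 3 `C=CCN1C[C@@H](OCc2ccccc2)[C@@H](CNc2ccnc3cc(Cl)ccc23)C(C)(C)C1`: 122000 nM

Compound 2, at 211000 nM, lies within the scatter of compound 3, and its number is higher than that of compound 1 by a gap beyond the scatter.

Compound 4 `C=CCN1C[C@@H](OCc2ccccc2)[C@@H](CNCc2ccnc3ccccc23)C(C)(C)C1` has quinolin-4-yl in place of quinolin-2-yl on a saturated chain carbon bound to an amine nitrogen. For the measured compounds named here, no measured pair isolates this change. Compound 3, at 122000 nM, is the only nearby reference, so a small downward drift in this assay is expected, and nothing beyond the scatter. The estimated step of a 1.3-fold lower number from compound 2 to compound 4 (0.12 log units; within the scatter) remains within the scatter. For compound 4 the estimate is 160000 nM, with an expected range of 85000 nM to 300000 nM.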

Compound 4, half-maximal inhibitory concentration: 139000 nM
Compound 4: middle estimate off by 1.2-fold (0.06 log units), on the high side; measured number inside the range.
By their numbers in this assay, from the lowest: compound 1; then compounds 3, 4 and 2 (each within the scatter of the next).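

In this assay, for the compounds shown here, quinolin-4-yl in place of quinolin-2-yl on a saturated chain carbon bound to an amine nitrogen gives a 1.5-fold lower number from compound 2 to compound 4 (0.18 log units; within the scatter), the only pair here that isolates this change. At this place, the two quinoline attachments are therefore not told apart by this assay. No measurement bears on the reason for this.

From the compounds shown here alone, it remains open whether a pyridin-4-yl or a phenyl group at this place would stay within the scatter of compound 2. The same holds for a longer chain carrying quinolin-4-yl.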